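A few compounds are considered here, and "the series" means these few. Any claim that something is new, unique, unknown or untested is made for them only; others in the source may bear on it.

Working notes on the series. Compound 1 `COc1ccc(CNC(=O)c2cn(-c3nccs3)nc2CC(C)C)cc1` sets the reference point. In a toxicity assay on HepG2 2.2.15 cells (Homo sapiens) for cytotoxicity, read by CCK-8 assay, with a stated time of 8 days (a lower number here means that less compound is tolerated, a higher number that more compound is tolerated), compound 1 gives > 100000 nM, which is a limit of the assay and not a number, so it stands at the limit of > 100000 nM in this assay, at which 1 of the 2 values shown sits, rather than at a measured value. Compound 2 `COc1ccc(CONC(=O)c2cn(-c3cccc(F)c3)nc2CC(C)C)cc1` in this assay gives 67900 nM. Compound 3 `CC(C)Cc1nn(-c2nccs2)cc1C(=O)NCc1ccc(N)cc1` differs from compound 1 only in that (amino in place of methoxy on an aromatic carbon). Within the data shown here, no measured step of this kind is available, so the expected step from compound 1 to compound 3, a step that the limit leaves unreadable from compound 1 to compound 3, is estimated to stay within the scatter, with no shift beyond it in either direction. For compound 3 the estimate in this assay is 110000 nM, in a range from 50000 nM to 250000 nM.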

Compound 3, half-maximal cytotoxic concentration: > 100000 nM
Compound 3 ended at the assay's limit; the forecaster's own chance of this, stated with the estimate: 55%; the middle value does not contradict the limit.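

Compound 1 and compound 3 both stand at a limit of the assay, so no step between them can be read: the limit of > 100000 nM in this assay, at which 2 of the 3 values shown sit.

Left open is whether amino in place of methoxy on an aromatic carbon shifts the tolerated concentration in this assay at all.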